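Halogen swap on the acylurea aryl of compound 1

This account rests on a few compounds, and the source may have more. Where it says the series, first, only, none or still open, it means among the compounds named here.

Compound 1 `CN(C(=O)NC(=O)c1c(Cl)cccc1Cl)c1nc(C(F)(F)F)c(C(=O)N/N=C/c2ccccc2C(F)(F)F)s1` stands second highest of the three numbers measured in a functional assay on MCF7 cells (Homo sapiens) for inhibition, read by MTT assay, with a stated time of 72 h (a higher number here means a weaker inhibitor, a lower number a stronger inhibitor), where compound 1 gives 6.24 ug/mL. Compound 2 `CN(C(=O)NC(=O)c1ccc([N+](=O)[O-])cc1)c1nc(C(F)(F)F)c(C(=O)N/N=C/c2cccc(C(F)(F)F)c2)s1` gives 4.39 ug/mL in this assay, and compound 3 `Cc1nc(N(C)C(=O)NC(=O)c2c(F)cccc2F)sc1C(=O)N/N=C/c1cc(C(F)(F)F)cc(C(F)(F)F)c1` gives 11.6 ug/mL; both gaps to compound 1 fall within the scatter, so the three cannot be ranked. Within the data shown here, no pair of measured compounds differs in a single place, so no step is known. Compound 4 `CN(C(=O)NC(=O)c1c(F)cccc1F)c1nc(C(F)(F)F)c(C(=O)N/N=C/c2ccccc2C(F)(F)F)s1` differs from compound 1 by 2,6-difluorophenyl in place of 2,6-dichlorophenyl on a carbonyl carbon. Nothing measured isolates this change, so only a small step is expected in this assay, with no direction beyond the scatter. For compound 4 the estimate is 7 ug/mL, between 3 ug/mL and 16 ug/mL. The expected step of a 1.1-fold higher number from compound 1 to compound 4 (0.05 log units; within the scatter) is therefore expected to stay inside the scatter.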

Compound 4, half-maximal inhibitory concentration: 20.4 ug/mL
Estimate against measurement, compound 4: 2.9-fold (0.46 log units) below; measured number outside the range, above it.
By their numbers in this assay, from the lowest: compounds 2, 1, 3 and 4 (each within the scatter of the next, the first and the last beyond it).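

Among these compounds, the 2,6-dichlorophenyl on this carbonyl carbon is not freely exchangeable: with the rest of compound 1 unchanged, 2,6-difluorophenyl in its place gives a 3.3-fold higher number from compound 1 to compound 4 (0.51 log units; beyond the scatter) in this assay, the only single-place step so far. Compound 4 is the weaker inhibitor of this pair. Nothing measured here accounts for the step.

On these data alone, whether the same swap has a similar effect with other groups elsewhere on the shared core remains open. Also open, as far as these compounds go, is how 2,6-dibromophenyl or 2,6-dimethylphenyl would read on this carbonyl carbon.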